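A few compounds are considered here, and "the series" means these few. Any claim that something is new, unique, unknown or untested is made for them only; others in the source may bear on it.

Compound 1 `COc1ccc(/C=C/C(=O)/C=C/c2nc(C)c(C)nc2C)cc1` gives 3500 nM
Compound 2 `Cc1nc(C)c(/C=C/C(=O)/C=C/c2ccc(Cl)cc2)nc1C` gives 15800 nM

In a functional assay on A549 cells (Homo sapiens) for antiproliferative activity, read by MTT assay, with a stated time of 72 h (a lower number here means a stronger inhibitor, a higher number a weaker inhibitor), compound 2 gives 15800 nM and so holds the higher of the two numbers, making it the weaker inhibitor of the pair. Compound 3 `Cc1nc(C)c(/C=C/C(=O)/C=C/c2ccc(C(F)(F)F)cc2)nc1C` keeps the core of compound 2 and alters one group, with trifluoromethyl in place of chloro on an aromatic carbon para to a large group. For the measured compounds named here, only one measured step bears on this change. Replacing methoxy with chloro at that same aromatic carbon gave a 4.5-fold higher number from compound 1 to compound 2 (0.65 log units; beyond the scatter) and counts as modest in size. That step shows that the number in this assay can respond to a swap at this carbon, but it involves a different pair of groups. Going by the values given here, no compound with trifluoromethyl has been measured, so the data support no firm direction. A step no larger than the measured one is expected, most likely none beyond the scatter. The value expected for compound 3 is 15000 nM (estimated range 6000 nM to 36000 nM) in this assay under the same conditions. This estimate amounts to a 1.1-fold lower number from compound 2 to compound 3 (0.02 log units; within the scatter) as the expected step.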

Compound 3, half-maximal inhibitory concentration: 11700 nM
The estimate for compound 3 lay 1.3-fold (0.11 log units) above the measured number; measured number inside the range.
By their numbers in this assay, from the lowest: compound 1; then compounds 3 and 2 (each within the scatter of the next).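

In this assay, trifluoromethyl in place of chloro on the aromatic carbon para to a large group gives a 1.4-fold lower number from compound 2 to compound 3 (0.13 log units; within the scatter), so this position does not separate the two groups, even though trifluoromethyl brings four heavy atoms where chloro brings one. Methoxy now stands apart from both: a 3.3-fold higher number from compound 1 to compound 3 (0.52 log units; beyond the scatter) sits alongside a 4.5-fold higher number from compound 1 to compound 2 (0.65 log units; beyond the scatter), so a higher number on leaving methoxy, which earlier rested on chloro alone, is seen with two different groups at this carbon. Nothing measured here explains this difference between methoxy and the other two groups.

From the compounds shown here alone, it remains open whether the lower number of compound 1 belongs to methoxy itself or would also appear with other groups on this carbon, such as a hydroxyl, an amine or a longer ether chain. Also open, going by these compounds, is how the number responds to changes elsewhere on the shared core, since all three compounds differ only at this one carbon.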